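Triazole in place of the bicyclic amide substituent

A few compounds are considered here, and "the series" means these few. Any claim that something is new, unique, unknown or untested is made for them only; others in the source may bear on it.

Two compounds of the series have numbers in a functional assay on CHO-K1 cells for antagonist activity at C-X-C chemokine receptor type 3 (Homo sapiens), read by FLIPR, with a stated time of 10 min; on this read-out lower numbers stand for stronger inhibition and higher numbers for weaker inhibition. Compound 1 `C[C@@H]1CN(c2sc(C3CC3)nc2-c2nc3ccccc3[nH]2)CCN1C(=O)Cn1cnc2cccnc21` gives 9.7 nM in this assay. Compound 2 `CCOc1ncc(-c2nc(C(F)(F)F)sc2N2CCN(C(=O)Cn3ncc4cccnc43)[C@H](C)C2)cn1` gives 4.1 nM in this assay, the lower of the two numbers; compound 1 stands beyond the scatter above it. The two compounds differ in more than one place, so their gap is not tied to any single change.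

Compound 3 `CCOc1ncc(-c2nc(C(F)(F)F)sc2N2CCN(C(=O)Cn3cnc(C(F)(F)F)n3)[C@H](C)C2)cn1` is not yet measured. It differs from compound 2 in one place: a group of 9 heavy atoms (3 carbon, 3 nitrogen, 3 fluorine; one five-membered aromatic ring with 3 hetero atoms) in place of a group of 9 heavy atoms (6 carbon, 3 nitrogen; one five-membered aromatic ring with 2 hetero atoms, one six-membered aromatic ring with 1 hetero atom), on a saturated chain carbon bound to a carbonyl carbon. Among the compounds with values here, no measured pair shows this kind of change, so its size has to be guessed. The pair of compounds 1 and 2 at least shows that the group on the saturated chain carbon bound to the carbonyl carbon matters for the number in this assay. Replacing a fused two-ring group by a single five-membered ring carrying a trifluoromethyl is a larger change than that between compound 1 and compound 2, and a weakening beyond the scatter is expected, though with wide uncertainty in either direction. For compound 3 the expectation in this assay is 15 nM, within 4 nM to 60 nM. The expected step is a 3.7-fold higher number from compound 2 to compound 3 (0.56 log units; beyond the scatter).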

Compound 3, half-maximal inhibitory concentration: 3.8 nM
The estimate for compound 3 lay 3.9-fold (0.60 log units) above the measured number; the measured number lies below the stated range.
By their numbers in this assay, from the lowest: compounds 3 and 2 (each within the scatter of the next); then compound 1.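

In this assay, the step from the fused two-ring group to 3-(trifluoromethyl)-1H-1,2,4-triazol-1-yl on the saturated chain carbon bound to a carbonyl carbon is a 1.1-fold lower number from compound 2 to compound 3 (0.03 log units; within the scatter). On the core shared by these two compounds, a single five-membered aromatic ring with 3 hetero atoms and a trifluoromethyl therefore serves as well as the fused group with its six-membered aromatic ring, and the two numbers cannot be told apart. Within the data shown here, this is the first reading at this position tied to one change, as the earlier pair differed in more than one place; nothing available explains why the two groups match.

Open, as far as these compounds go, is what a methyl, a nitrile or a plain hydrogen in place of the trifluoromethyl on the triazole would do to the number in this assay, and so how much of it rests on that group. Also open, from the compounds shown here alone, is whether the same triazole would match the fused group on the core of compound 1, which carries a different pair of substituents.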